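Lengthening the side chain of compound 1 with a small ring

The source may report more compounds than this note shows. Statements on the series, on what has been measured and on what is new or still open speak of the compounds shown alone.

Compound 1 `CCC[C@H](c1ccc(C(=O)NCc2nn[nH]n2)cc1)N1C(=O)C(c2cc(Cl)cc(Cl)c2)=N[C@]12CC[C@@H](C(C)(C)C)CC2` gives 500 nM in an assay on membranes from liver for displacement of a labelled ligand from Glucagon receptor (Mus musculus), read by scintillation counting, with a stated time of 60 min (on this read-out lower numbers stand for stronger inhibition and higher numbers for weaker inhibition), the lowest of the two numbers recorded. Among the compounds with values here, the only other measured compound, compound 2 `CC(C)(C)[C@H]1CC[C@]2(CC1)N=C(c1ccc(C(F)(F)F)cc1)C(=O)N2Cc1ccc(C(=O)NCCC(=O)O)cc1`, gives 9600 nM in this assay, a number well beyond the scatter above that of compound 1; the two compounds differ in several places at once, so no single change can be read from the pair. Compound 3 `CC1(CC[C@H](c2ccc(C(=O)NCc3nn[nH]n3)cc2)N2C(=O)C(c3cc(Cl)cc(Cl)c3)=N[C@]23CC[C@@H](C(C)(C)C)CC3)CC1` has not yet been measured in this assay. It differs from compound 1 by 1-methylcyclopropyl in place of methyl on a saturated chain carbon, three bonds along the chain from an amide-type nitrogen in a ring and an aromatic carbon. Within the data shown here, no measured pair shows what such a change does on this core, so the expectation rests on compound 1 alone. The step from compound 1 to compound 3 is estimated at a 1.3-fold lower number from compound 1 to compound 3 (0.10 log units; within the scatter), a change not clearly beyond the scatter in either direction. Compound 3 is therefore expected to give about 400 nM in this assay, within a range of 120 nM to 1500 nM.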

Compound 3, half-maximal inhibitory concentration: 110 nM
Compound 3: middle estimate off by 3.6-fold (0.56 log units), on the high side, and the stated range ends above it.
By their numbers in this assay, from the lowest: compound 3; then compound 1; then compound 2.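

In this assay, replacing methyl with 1-methylcyclopropyl on a saturated chain carbon, three bonds along the chain from an amide-type nitrogen in a ring and an aromatic carbon, gives a 4.5-fold lower number from compound 1 to compound 3 (0.66 log units; beyond the scatter). Within the data shown here, this is the first single change that can be read on this series, and it shows that the side chain of compound 1 can carry a larger end group, here with a three-membered ring, and still give a lower number. Nothing available here explains the shift.

The compounds shown do not separate the effect of the ring from that of the added carbons, as an open pentyl chain or a cyclopropyl group lacking the methyl could. They also leave open how a hydroxyl group or an amine at this chain end would read.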